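Methoxy for chloro on the aryl ring of compound 1

The source may hold more compounds than are shown below. What is called first, only, known or untested is meant among the compounds shown, and "the series" means these compounds.

Measured so far:
compound 1, `Cc1nc(-c2ccc(Cl)cc2)sc1C(=O)CSc1nc(-c2ccc(Cl)c(Cl)c2)c(C#N)c(=O)[nH]1`: 101%
compound 2, `COc1ccc(-c2nc(SCC(=O)c3sc(-c4ccccc4)nc3C)nc(N)c2C#N)cc1`: 68.8%
compound 3, `COc1ccc(-c2nc(C)c(C(=O)CSc3nc(N)c(C#N)c(-c4ccc(OC)cc4)n3)s2)cc1`: 35.6%

In a functional assay on U-87MG ATCC cells for antiproliferative activity against U-87 MG (Homo sapiens), read by MTT assay, with a stated time of 48 h, tested at 5 uM (a lower number here means a stronger effect, a higher number a weaker effect of the compound at the concentration tested), compound 1 gives 101%, the highest of the three numbers; its steps to compound 2 and to compound 3 both lie beyond the scatter. Compound 4, `COc1ccc(-c2nc(C)c(C(=O)CSc3nc(-c4ccc(Cl)c(Cl)c4)c(C#N)c(=O)[nH]3)s2)cc1`, is not yet measured. It differs from compound 1 by methoxy in place of chloro on an aromatic carbon. Going by the values given here, one measured step bears on this change, a methoxy entering on an aromatic carbon: a number 33.2 percentage points lower from compound 2 to compound 3 (beyond the scatter). A fall of comparable size is expected for compound 4 in this assay, namely a number 31 percentage points lower from compound 1 to compound 4 (beyond the scatter), because a number 33.2 percentage points lower from compound 2 to compound 3 (beyond the scatter) was large. Among the compounds with values here, the chloro that leaves here has no measured counterpart, so the range is kept wide. For compound 4 the expected value is 70%, between 45% and 98%.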

Compound 4, a percentage reported as activity, at one concentration (the size of the read-out at that concentration, not a potency): 101%
The estimate for compound 4 lay 31 percentage points below the measured number; measured number above the stated range.
By their numbers in this assay, from the lowest: compound 3; then compound 2; then compounds 1 and 4 (each within the scatter of the next).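

In this assay, going from 4-chlorophenyl to 4-methoxyphenyl gives no change at the digits printed from compound 1 to compound 4 (within the scatter), so on the core of compound 1 this position tolerates the exchange with no readable effect. The methoxy step a number 33.2 percentage points lower from compound 2 to compound 3 (beyond the scatter) therefore does not carry over to a methoxy replacing chloro on this core. No measurement shown accounts for the contrast between the two steps.

From the compounds shown here alone, whether chloro in place of methoxy on compound 3 would reverse its step remains open. So does whether an amine or a carboxylic acid at this position on compound 1 would shift the read-out.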